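Lengthening the chain from compound 3 to compound 4

The source may report more compounds than this note shows. Statements on the series, on what has been measured and on what is new or still open speak of the compounds shown alone.

- compound 1 `CCCCCCCNC[C@@H]1OC[C@H](N)[C@@H]1O` gives > 128000 nM as a limit of the assay
- compound 3 `CCCCCCCCCNC[C@@H]1OC[C@H](N)[C@@H]1O` gives 22100 nM as a measured value
- compound 2 `CCCCCCCCCCCCNC[C@@H]1OC[C@H](N)[C@@H]1O` gives 5870 nM as a measured value

All readings come from a functional assay on A549 cells (Homo sapiens) for antiproliferative activity, read by MTT assay, with a stated time of 72 h (on this read-out higher numbers stand for weaker inhibition and lower numbers for stronger inhibition), in this series. Of the two true numbers, compound 3 at 22100 nM is the higher and stands above compound 2 at 5870 nM on this scale.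

Compound 4 `CCCCCCCCCCCCCCNC[C@@H]1OC[C@H](N)[C@@H]1O` is still unmeasured. The change is pentyl in place of hydrogen on a saturated chain carbon, nine bonds along the chain from an amine nitrogen on a saturated chain carbon, nine bonds along the chain from an amine nitrogen.

Among the compounds with values here, the nearest precedent is the same pentyl addition seven bonds along the chain, where an at least 21-fold lower number from compound 1 to compound 2 (1.33 log units; beyond the scatter) is a large step, though it starts from a limit. The smaller addition gives an at least 5.7-fold lower number from compound 1 to compound 3 (0.76 log units; beyond the scatter) and is at least modest. Only a 3.8-fold higher number from compound 2 to compound 3 (0.58 log units; beyond the scatter) joins two true numbers, and it is modest. All three compounds show lower numbers with longer chains and none goes against this, but nothing shows the trend continuing past compound 2. A further modest to large fall is therefore expected in this assay for this step.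

The estimate means a 7.4-fold lower number from compound 3 to compound 4 (0.87 log units; beyond the scatter) as the expected step. For compound 4 the expected value is 3000 nM within an estimated range of 1200 nM to 8000 nM in this assay.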

Compound 4, half-maximal inhibitory concentration: 2850 nM
The estimate for compound 4 lay 1.1-fold (0.02 log units) above the measured number; low and high end bracket the measured number.
By their numbers in this assay, from the lowest: compound 4; then compound 2; then compound 3. At a limit, above all of these: compound 1.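

The fall with chain length in this assay continues past the longest chain measured earlier, with a 2.1-fold lower number from compound 2 to compound 4 (0.31 log units; beyond the scatter), and no compound shown goes against it. Pentyl in place of hydrogen nine bonds along the chain from an amine nitrogen gives a 7.8-fold lower number from compound 3 to compound 4 (0.89 log units; beyond the scatter), a step between two true numbers, and it is smaller than the same change seven bonds along, though that earlier step starts from a limit: the same change on two cores in this assay, an at least 21-fold lower number (1.33 log units; beyond the scatter) from compound 1 to compound 2 and a 7.8-fold lower number (0.89 log units; beyond the scatter) from compound 3 to compound 4, at least 2.8-fold (0.44 log units) apart, beyond the scatter of two such steps The ethyl addition also gives less further out along the chain, while the full heptyl addition gives an at least 44-fold lower number from compound 1 to compound 4 (1.65 log units; beyond the scatter), again a step that starts from a limit: the same change on two cores in this assay, an at least 5.7-fold lower number (0.76 log units; beyond the scatter) from compound 1 to compound 3 and a 2.1-fold lower number (0.31 log units; beyond the scatter) from compound 2 to compound 4, at least 2.8-fold (0.44 log units) apart, beyond the scatter of two such steps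

From the compounds shown here alone, whether the numbers keep falling with a longer chain, level off or turn back stays open, as the shrinking steps do not settle it. Also open is how a chain ending in a phenyl ring, a carboxylic acid or a second amine would read in this assay, since every compound shown carries a plain saturated chain on the shared core.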